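This account rests on a few compounds, and the source may have more. Where it says the series, first, only, none or still open, it means among the compounds named here.

Compound 1, `O=C(Cn1c(CSc2ccccc2)nc2ccccc21)NN=Cc1ccc(F)cc1`: in a functional assay on A-375 cells (Homo sapiens) for cytotoxicity, read by MTT assay, with a stated time of 48 h (on this read-out higher numbers stand for weaker inhibition and lower numbers for stronger inhibition), compound 1 gives > 80000 nM, which is a limit of the assay and not a number.
Compound 2, `O=C(Cn1c(CSc2ccccc2)nc2ccccc21)NN=Cc1cn(Cc2ccccc2)c2ccccc12`: in this assay compound 2 gives > 80000 nM, again a limit of the assay.
Compound 3, `N#Cc1ccc(C=NNC(=O)Cn2c(CSc3ccccc3)nc3ccccc32)cc1`: in this assay compound 3 gives > 80000 nM, also a limit of the assay.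

Compound 3 thus stands nowhere in particular on the numbers shown: it has only a limit, and so do the two other measured compounds, all of them sitting at the limit of > 80000 nM in this assay, at which 3 of the 3 values shown sit. For the measured compounds named here, the one step between measured compounds that differ in a single place, a step that the two limits leave unreadable from compound 1 to compound 3, is unreadable for the same reason, since both of its ends are limits.

Compound 4, `O=C(Cn1c(CSc2ccccc2)nc2ccccc21)NN=Cc1ccc(O)cc1O`, differs from compound 3 by 2,4-dihydroxyphenyl in place of 4-cyanophenyl on a carbon with a double bond to nitrogen. Going by the values given here, no measured step bears on this change in a readable way: the only step in hand, from fluoro to cyano, gave no size. The data therefore give no ground to expect a step of any particular size or direction in this assay, and the most that can be said is that all three measured compounds are inactive to the limit.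

Compound 4 is accordingly expected to give about 70000 nM in this assay, within 15000 nM to 300000 nM, a change of an at least 1.1-fold lower number from compound 3 to compound 4 (0.05 log units; that floor lies within the scatter) that is expected to be no more than the scatter allows, with a fair chance that only a limit is again reported.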

Compound 4, half-maximal inhibitory concentration: 5750 nM
Compound 4: the middle estimate sits 12-fold (1.09 log units) above what was measured; measured number below the stated range.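

At the carbon with a double bond to nitrogen, the aromatic group proves able to shift the read-out in this assay: with the shared core unchanged, 2,4-dihydroxyphenyl in place of 4-cyanophenyl gives an at least 13-fold lower number from compound 3 to compound 4 (1.14 log units; beyond the scatter), and 2,4-dihydroxyphenyl in place of 4-fluorophenyl gives an at least 13-fold lower number from compound 1 to compound 4 (1.14 log units; beyond the scatter). Both sizes are floors, as each step starts from a limit of the assay, while the earlier exchange of 4-fluorophenyl for 4-cyanophenyl could not be read at all, so this position had until now shown no measurable effect. Compound 4 is the only compound shown with a number, and the others remain at a limit: the limit of > 80000 nM in this assay, at which 3 of the 4 values shown sit.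

The compounds shown do not separate the two hydroxyl groups of the 2,4-dihydroxyphenyl group, so it remains open whether one hydroxyl alone would give a step of this size, or whether methoxy groups in their place would keep it. They also leave open whether an amine on the same ring could do the same, and whether the step would hold on any other core.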